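A few compounds are considered here, and "the series" means these few. Any claim that something is new, unique, unknown or untested is made for them only; others in the source may bear on it.

Working notes on the series. Among the compounds with values here, in a functional assay on MDA-MB-231 cells (Homo sapiens), read by microscopy and transwell migration, with a stated time of 24 h (on this read-out higher numbers stand for weaker inhibition and lower numbers for stronger inhibition), compound 2 `CCCCCCCCCCCCn1c(-c2ccc(C)cc2C)cs/c1=N\C(=O)c1ccccc1` gives 24 nM, the lower of the two numbers so far, while compound 1 `Cc1ccc(-c2cs/c(=N\C(=O)c3ccccc3)n2C)c(C)c1` gives 218 nM. The next structure is compound 3 `C=CCn1c(-c2ccc(C)cc2C)cs/c1=N\C(=O)c1ccccc1`, and its change from compound 2 is vinyl in place of undecyl on a saturated chain carbon bound to an aromatic nitrogen. Within the data shown here, one measured step bears on this change: a 9.1-fold lower number from compound 1 to compound 2 (0.96 log units; beyond the scatter), with undecyl in place of hydrogen at that same carbon. That step is modest but beyond the scatter. With vinyl in place of undecyl, compound 3 is expected to lie nearer compound 1 at 218 nM, so a step of similar size towards a higher number is expected in this assay. The data do not show what the double bond contributes on its own. The expected step is a 6.3-fold higher number from compound 2 to compound 3 (0.80 log units; beyond the scatter). For compound 3 the estimated value is 150 nM, with an expected range of 50 nM to 450 nM.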

Compound 3, half-maximal inhibitory concentration: 456 nM
The estimate for compound 3 lay 3.0-fold (0.48 log units) below the measured number; the measured number lies above the stated range.
By their numbers in this assay, from the lowest: compound 2; then compound 1; then compound 3.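

In this assay, vinyl in place of undecyl gives a 19-fold higher number from compound 2 to compound 3 (1.28 log units; beyond the scatter) and does not keep the low number of compound 2. Vinyl in place of hydrogen gives a 2.1-fold higher number from compound 1 to compound 3 (0.32 log units; beyond the scatter) and so shows that a group on this saturated chain carbon bound to an aromatic nitrogen can also move the number upward, whereas undecyl moved it downward. The order therefore does not follow group size across these three compounds: compound 1, which carries hydrogen, falls in the middle and compound 3, which carries vinyl, has the highest number.

From the compounds shown here alone, whether a propyl chain, a longer chain than undecyl or a chain bearing an amine would give a low or a high number at this carbon remains open. No measurement shown here explains why vinyl and undecyl move the number in opposite directions.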